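The compounds below may be only part of what the source reports. "The series", "measured", "known", "first", "only" and "open" are said of these compounds alone.

Measured in an ADME assay on Huh-7 cells (Homo sapiens) for cytotoxicity, with a stated time of 72 h; a higher number here means that more compound is tolerated, a lower number that less compound is tolerated:
- compound 1 `COCN(c1ccc2c(c1)S(=O)(=O)N=C(c1c(O)c(-c3cccs3)nn(CCC(C)C)c1=O)N2)S(C)(=O)=O`: > 1000 nM (a limit)
- compound 2 `CC(C)CCn1nc(-c2cccs2)c(O)c(C2=NS(=O)(=O)c3cc(S(N)(=O)=O)ccc3N2)c1=O`: > 33000 nM (a limit)
- compound 3 `CC(C)CCn1nc(-c2ccccc2)c(O)c(C2=NS(=O)(=O)c3cc(NS(C)(=O)=O)ccc3N2)c1=O`: > 1000 nM (a limit)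

None of these three results is an exact number. Compound 3 sits at the limit of > 1000 nM in this assay, at which 2 of the 3 values shown sit, alongside compound 1.

Compound 4 `C/C(=C\c1nn(CCC(C)C)c(=O)c(C2=NS(=O)(=O)c3cc(NS(C)(=O)=O)ccc3N2)c1O)C(F)(F)F` carries 2-(trifluoromethyl)prop-1-en-1-yl in place of phenyl on an aromatic carbon.

Among the compounds with values here, only one measured step exists, a step that the two limits leave unreadable from compound 1 to compound 2. It swaps a different group and has no readable size, so it offers nothing to carry over.

The expected step, a step that the limit leaves unreadable from compound 3 to compound 4, therefore has no firm size, and no clear move towards lower tolerance is expected. Compound 4 is estimated at 5000 nM, with an expected range from 1000 nM to 33000 nM.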

Compound 4, half-maximal cytotoxic concentration: > 33000 nM
Compound 4: no number, only a limit (the forecaster's own chance of this, stated with the estimate: 85%); middle value at least 6.6-fold (0.81 log units) away from the limit.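

Compound 3 and compound 4 each give only a limit in this assay, and the step between them cannot be read. The exact tolerated concentration of each compound shown remains open.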